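The source may report more compounds than this note shows. Statements on the series, on what has been measured and on what is new or still open speak of the compounds shown alone.

In an assay on isolated protein for inhibition of Death-associated protein kinase 3 (Homo sapiens), tested at 1 uM (on this read-out higher numbers stand for a stronger effect at the one concentration tested and lower numbers for a weaker effect), compound 1 `COc1cccc(C2=N/C(=C\c3cccnc3)C(=O)O2)c1` gives 99%, and compound 3 `O=C1OC(c2ccc(Cl)c([N+](=O)[O-])c2)=N/C1=C\c1cccnc1` gives 100%. Compound 2 `COc1cc(C2=N/C(=C\c3cccnc3)C(=O)O2)cc(OC)c1OC` stands lowest of the three in this assay, with 26%, a reading that lies beyond the scatter below both of the others. Compound 4 `COc1ccc(C2=N/C(=C\c3cccnc3)C(=O)O2)cc1OC` has not yet been measured in this assay. It differs from compound 2 in one place: hydrogen in place of methoxy on an aromatic carbon. Among the compounds with values here, no step between measured compounds fits this change, so the expectation rests on the readings at hand. With compound 1 giving 99% while compound 2 gives only 26%, a rise beyond the scatter is expected, the estimated step being a number 44 percentage points higher from compound 2 to compound 4 (beyond the scatter). Compound 4 is therefore expected to reach about 70%, within a range from 35% to 95%.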

Compound 4, a percentage reported as inhibition, at one concentration (the size of the read-out at that concentration, not a potency): 14%
Compound 4: the middle estimate sits 56 percentage points above what was measured, and the stated range ends above it.
By their numbers in this assay, from the lowest: compound 4; then compound 2; then compounds 1 and 3 (each within the scatter of the next).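

In this assay, hydrogen in place of methoxy on this aromatic carbon, ortho to a methoxy group, gives a number 12 percentage points lower from compound 2 to compound 4 (beyond the scatter), so removing this methoxy does not restore the effect. The much larger change lies in the other step, where methoxy in place of hydrogen on an aromatic carbon gives a number 85 percentage points lower from compound 1 to compound 4 (beyond the scatter), so one added methoxy is enough to take the reading down this far. Nothing available explains either step. From the compounds shown here alone, whether a hydroxyl, a fluorine or an amine on this carbon would read like hydrogen or like methoxy remains open.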